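Replacing diethylamino with chloro in compound 2

The compounds below may be only part of what the source reports. "The series", "measured", "known", "first", "only" and "open" are said of these compounds alone.

- compound 1 `CCSC(=S)SCC(=O)c1ccccc1` gives 5010 nM
- compound 2 `CCSC(=S)SCC(=O)c1ccc(N(CC)CC)cc1` gives 3160 nM

In a functional assay on HeLa cells (Homo sapiens) for antiproliferative activity, read by resazurin assay (on this read-out lower numbers stand for stronger inhibition and higher numbers for weaker inhibition), compound 2 gives 3160 nM. Within the data shown here, only one other measurement sits alongside it, and the step between them is a 1.6-fold lower number from compound 1 to compound 2 (0.20 log units; within the scatter). That step lies within the usual scatter of repeated measurements, so the two compounds cannot be ranked.

The next compound, compound 3 `CCSC(=S)SCC(=O)c1ccc(Cl)cc1`, has chloro in place of diethylamino on an aromatic carbon.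

Among the measured compounds shown here, the one measured step that bears on this change is a 1.6-fold lower number from compound 1 to compound 2 (0.20 log units; within the scatter), which placed diethylamino on that aromatic carbon and stayed within the scatter. For the measured compounds named here, no measured compound carries chloro, so the evidence is thin. In this assay no shift beyond the scatter is therefore expected, and the expected step is a 1.1-fold higher number from compound 2 to compound 3 (0.04 log units; within the scatter).

Compound 3 is estimated at 3500 nM, with an expected range from 1500 nM to 8000 nM.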

Compound 3, half-maximal inhibitory concentration: 5010 nM
Compound 3: the middle estimate sits 1.4-fold (0.16 log units) below what was measured; measured number inside the range.
By their numbers in this assay, from the lowest: compounds 2, 1 and 3 (each within the scatter of the next).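

In this assay chloro in place of hydrogen on this aromatic carbon gives no change at the digits printed from compound 1 to compound 3 (within the scatter) and chloro in place of diethylamino gives a 1.6-fold higher number from compound 2 to compound 3 (0.20 log units; within the scatter) on the same read-out. Hydrogen, diethylamino with its 5 heavy atoms, and chloro with its single atom therefore all lie within the scatter of one another, so none of these three groups can be ranked against the others at this position. No measurement here offers an explanation for this flat result.

The compounds shown leave open whether a carboxylic acid or a primary amine on this carbon would move the number beyond the scatter. On these data alone, whether a change elsewhere in the shared core, such as a longer chain in place of the ethyl group, would do so also remains open.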